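Swapping Chloro for Bromo on the Sulfonyl Aryl Ring

A few compounds are considered here, and "the series" means these few. Any claim that something is new, unique, unknown or untested is made for them only; others in the source may bear on it.

Compound 1 `O=C1/C(=C/c2ccccc2F)CN(S(=O)(=O)c2ccc(Cl)cc2)C/C1=C\c1ccccc1F`: 10900 nM
Compound 2 `O=C1/C(=C/c2ccccc2F)CN(S(=O)(=O)c2ccc(Br)cc2)C/C1=C\c1ccccc1F`: 13700 nM
Compound 3 `O=C1/C(=C/c2ccc(F)cc2)CN(S(=O)(=O)c2ccc(Cl)cc2)C/C1=C\c1ccc(F)cc1`: 4500 nM

Of the compounds shown here, three have been tested in a functional assay on HepG2 cells (Homo sapiens) for cytotoxicity, read by MTT assay, with a stated time of 24 h; a higher number here means a weaker inhibitor, a lower number a stronger inhibitor. In this assay compound 1 gives 10900 nM, compound 2 gives 13700 nM, and compound 3 gives 4500 nM. Compound 1 and compound 2 differ in a single place: bromo in place of chloro on an aromatic carbon. This change made a 1.3-fold higher number from compound 1 to compound 2 (0.10 log units; within the scatter), so the two values cannot be told apart with confidence. Compound 3 has the same atoms as compound 1 joined differently; the difference between the two cores is not broken down here, and its value is the lowest of the three, with both other values beyond the scatter above it.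

Compound 4 `O=C1/C(=C/c2ccc(F)cc2)CN(S(=O)(=O)c2ccc(Br)cc2)C/C1=C\c1ccc(F)cc1` has not yet been measured. It differs from compound 3 by bromo in place of chloro on an aromatic carbon, the same change that leads from compound 1 to compound 2, at the same kind of place. Since that earlier step was only a 1.3-fold higher number from compound 1 to compound 2 (0.10 log units; within the scatter), the step from compound 3 to compound 4 is expected to be similarly small, about a 1.3-fold higher number from compound 3 to compound 4 (0.11 log units; within the scatter). Compound 4 is therefore estimated at 5800 nM, expected to fall between 2500 nM and 13000 nM.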

Compound 4, half-maximal inhibitory concentration: 8000 nM
Estimate against measurement, compound 4: 1.4-fold (0.14 log units) below; the range from low to high includes it.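

In this assay, replacing the 4-chlorophenyl with the 4-bromophenyl on the core of compound 3 gave a 1.8-fold higher number from compound 3 to compound 4 (0.25 log units; within the scatter) and so left no difference that can be told apart with confidence. Set beside the earlier step, the change looks much the same on both cores, with no sign that the core alters its outcome: the same change on two cores in this assay, a 1.3-fold higher number (0.10 log units; within the scatter) from compound 1 to compound 2 and a 1.8-fold higher number (0.25 log units; within the scatter) from compound 3 to compound 4, 1.4-fold (0.15 log units) apart, within the scatter of two such steps. This supports carrying the swap between these two cores in this assay, but two pairs are a small sample, so it sets no rule for other cores or other assays, and since both steps lie within the scatter, neither shows that bromo differs from chloro at all.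

The compounds shown leave open what happens when a quite different group, such as a methoxy group, an amine or a carboxylic acid, takes the place of the halogen on that ring. They also leave open whether the swap stays this small on a core carrying something other than fluoro on its outer rings.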